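This account rests on a few compounds, and the source may have more. Where it says the series, first, only, none or still open, it means among the compounds named here.

Compound 1 `CCN(CC)S(=O)(=O)c1ccc(S(=O)(=O)N2CCC[C@@H](C(=O)NC3CN(C(=O)C4CC4)C3)C2)cc1` stands second highest among the three numbers measured in a functional assay on MIA PaCa-2 cells (Homo sapiens) for inhibition, read by MTT assay, with a stated time of 7 days; a lower number here means a stronger inhibitor, a higher number a weaker inhibitor: compound 1 gives 2800 nM. Its nearest neighbour is compound 3 `CCOC(=O)[C@@H]1CCCN(S(=O)(=O)c2ccc(S(=O)(=O)N(CC)C(C)C)cc2)C1`, which gives 1000 nM, a lower number that lies beyond the scatter; furthest away is compound 2 `CCOC(=O)[C@H]1CCN(S(=O)(=O)c2ccc(S(=O)(=O)N(CC)CC)cc2)C1`, which gives 29200 nM, the highest number and also beyond the scatter from compound 1. Compound 4 `CCN(CC)S(=O)(=O)c1ccc(S(=O)(=O)N2CCC[C@@H](C(=O)NC3COC3)C2)cc1` is still to be measured in this assay. It differs from compound 1 in a single place: oxetan-3-yl in place of 1-(cyclopropylcarbonyl)azetidin-3-yl on an amide-type nitrogen. For the measured compounds named here, no pair of measured compounds shows a change of this kind, so the direction rests on the structures alone. The expected step is a 2.1-fold higher number from compound 1 to compound 4 (0.33 log units; beyond the scatter), toward a higher number, somewhat beyond the scatter. Compound 4 is therefore estimated at 6000 nM, within a range of 2000 nM to 18000 nM.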

Compound 4, half-maximal inhibitory concentration: 2300 nM
The estimate for compound 4 lay 2.6-fold (0.42 log units) above the measured number; the measured number falls inside the stated range.
By their numbers in this assay, from the lowest: compound 3; then compounds 4 and 1 (each within the scatter of the next); then compound 2.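

The step of a 1.2-fold lower number from compound 1 to compound 4 (0.09 log units; within the scatter) in this assay lies within the scatter, so this position on the amide-type nitrogen accepts oxetan-3-yl in place of 1-(cyclopropylcarbonyl)azetidin-3-yl with no readable change. The cyclopropylcarbonyl group and the azetidine ring can thus both leave this position without a shift beyond the scatter in this pair. Nothing available explains this result. The compounds shown leave open whether a free amine, such as unsubstituted azetidin-3-yl, or a longer open alkyl chain on this nitrogen would give a similar number.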